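A few compounds are considered here, and "the series" means these few. Any claim that something is new, unique, unknown or untested is made for them only; others in the source may bear on it.

Compounds measured so far:
compound 1, `Cc1ccc2nc(N3CCCc4ccc(F)cc4C3)cc(NCCN)c2c1`: > 3200 nM
compound 2, `Cc1ccc2nc(N3CCCc4ccc(F)cc4C3)cc(NCC(N)=O)c2c1`: 22000 nM
compound 3, `CC(=O)NCCNc1cc(N2CCCc3ccc(F)cc3C2)nc2ccc(C)cc12`: 66000 nM

In an ADME assay on HEp-2 cells (Homo sapiens) for cytotoxicity, read by CCK-8 assay, with a stated time of 5 days (on this read-out higher numbers stand for lower toxicity in this test and lower numbers for higher toxicity in this test), compound 3 gives 66000 nM, the highest of the two numbers that are numbers at all. The nearer of the others, compound 2, gives 22000 nM; the step of a 3.0-fold higher number from compound 2 to compound 3 (0.48 log units; beyond the scatter) is beyond the scatter, so compound 3 is the less toxic of the two. Compound 1 reaches only a limit of the test, > 3200 nM. The steps a step that the limit leaves unreadable from compound 1 to compound 2 and a step that the limit leaves unreadable from compound 1 to compound 3 cannot be read because of the limit of > 3200 nM in this assay, at which 1 of the 3 values shown sits.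

Compound 4, `Cc1ccc2nc(N3CCCc4ccc(F)cc4C3)cc(NC3(CN)COC3)c2c1`, has not yet been measured. It differs from compound 3 in one place: 3-(aminomethyl)oxetan-3-yl in place of 2-acetamidoethyl on a nitrogen on an aromatic ring. Within the data shown here, the entering group carries an aminomethyl like compound 1, yet the only step touching compound 1 is unreadable, and the only readable step, a 3.0-fold higher number from compound 2 to compound 3 (0.48 log units; beyond the scatter), is modest. Compound 3 is therefore expected to change by no more than a 2.2-fold lower number from compound 3 to compound 4 (0.34 log units; beyond the scatter), and compound 4 is estimated at 30000 nM, within 8000 nM to 100000 nM.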

Compound 4, half-maximal cytotoxic concentration: 86000 nM
Compound 4: the middle estimate sits 2.9-fold (0.46 log units) below what was measured; the range from low to high includes it.
By their numbers in this assay, from the lowest: compound 2; then compounds 3 and 4 (each within the scatter of the next).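

In this assay, replacing the open 2-acetamidoethyl on this nitrogen with 3-(aminomethyl)oxetan-3-yl, built from the same atoms joined differently, gives a 1.3-fold higher number from compound 3 to compound 4 (0.11 log units; within the scatter), so adding a four-membered ring in this rearrangement leaves the read-out within the scatter. The same group in place of carbamoylmethyl gives a 3.9-fold higher number from compound 2 to compound 4 (0.59 log units; beyond the scatter), which shows that an aminomethyl on this substituent can occur in a compound with a high number in this test. Compound 1 stands at a limit, and its steps to the other compounds cannot be read: the limit of > 3200 nM in this assay, at which 1 of the 4 values shown sits.

The compounds shown do not separate the part played by the oxetane ring from that of the aminomethyl, which a cyclobutane carrying aminomethyl or an oxetane without it could address. On these data alone, it also remains open how a carboxylic acid or a longer chain such as 3-aminopropyl on this nitrogen would read.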